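The source may report more compounds than this note shows. Statements on the series, on what has been measured and on what is new or still open speak of the compounds shown alone.

Measured in an ADME assay on HCT-116 cells (Homo sapiens) for cytotoxicity, read by CellTiter-Glo, with a stated time of 72 h; on this read-out higher numbers stand for weaker inhibition and lower numbers for stronger inhibition:
- compound 1 `CC1CCN(C2CCN(S(=O)(=O)c3cccnc3Cl)CC2)CC1`: > 10000 nM, a limit
- compound 2 `CC1CCN(C2CCN(S(=O)(=O)c3ccccc3Br)CC2)CC1`: > 5000 nM, a limit
- compound 3 `CC1CCN(C2CCN(S(=O)(=O)c3ccc(Cl)nc3)CC2)CC1`: > 10000 nM, a limit

None of the three has a true number. Compound 1 and compound 3 share (the limit of > 10000 nM in this assay, at which 2 of the 3 values shown sit), while compound 2 alone stands at the limit of > 5000 nM in this assay, at which 1 of the 3 values shown sits.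

The next compound, compound 4 `CC1CCN(C2CCN(S(=O)(=O)c3ccccc3-c3ccc(Cl)cc3)CC2)CC1`, differs from compound 2 by 4-chlorophenyl in place of bromo on an aromatic carbon. In words, 4-chlorophenyl stands in place of bromo on an aromatic carbon, ortho to a large group.

For the measured compounds named here, three measured steps bear on this part of the molecule: a step that the two limits leave unreadable from compound 1 to compound 2, a step that the two limits leave unreadable from compound 1 to compound 3 and a step that the two limits leave unreadable from compound 2 to compound 3. None of them has a readable size, and none replaces the bromo, so they offer no size to carry over.

Compound 2 offers only the limit > 5000 nM as a starting point, so a tentative move toward stronger inhibition in this assay is expected, with low confidence. The expected change is an at least 1.2-fold lower number from compound 2 to compound 4 (0.09 log units; that floor lies within the scatter), an estimate only. For compound 4 the estimate is 4000 nM, with an expected range from 1000 nM to 12000 nM.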

Compound 4, half-maximal inhibitory concentration: > 5000 nM
Compound 4 gave a limit, no number; the forecaster's own chance of this, stated with the estimate: 50%; middle value at least 1.2-fold (0.09 log units) away from the limit.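

In this assay compound 4 gives > 5000 nM, a limit and not a number, and compound 2 also has only a limit, so the step between them cannot be read. The compounds shown leave open whether 4-chlorophenyl in place of bromo changes inhibition at all.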